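Replacing Piperazine with Benzyl(methyl)amino on the Sulfonyl

The source may hold more compounds than are shown below. What is called first, only, known or untested is meant among the compounds shown, and "the series" means these compounds.

Compound 1 `CCOC(=O)[C@@H]1CCCN(S(=O)(=O)c2ccc(S(=O)(=O)N3CCCCC3)cc2)C1` gives 3300 nM in a functional assay on BXPC-3 cells (Homo sapiens) for inhibition, read by MTT assay, with a stated time of 7 days; a lower number here means a stronger inhibitor, a higher number a weaker inhibitor. Compound 2 `CCOC(=O)[C@@H]1CCCN(S(=O)(=O)c2ccc(S(=O)(=O)N(C)C)cc2)C1` gives 1000 nM in this assay, the change amounting to a 3.3-fold lower number from compound 1 to compound 2 (0.52 log units; beyond the scatter). Compound 3 `CCOC(=O)[C@@H]1CCCN(S(=O)(=O)c2ccc(S(=O)(=O)N3CCNCC3)cc2)C1` stands at the bottom of the three: in this assay compound 3 reaches only a limit of the assay, > 30000 nM, so its true number is not known. This is the limit of > 30000 nM in this assay, at which 1 of the 3 values shown sits. The measured steps leading to it are an at least 9.0-fold higher number from compound 1 to compound 3 (0.95 log units; beyond the scatter) and an at least 30-fold higher number from compound 2 to compound 3 (1.47 log units; beyond the scatter), both beyond the scatter.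

Compound 4 `CCOC(=O)[C@@H]1CCCN(S(=O)(=O)c2ccc(S(=O)(=O)N(C)Cc3ccccc3)cc2)C1` differs from compound 3 by benzyl(methyl)amino in place of piperazin-1-yl on a sulfonyl sulfur. Both steps ending at compound 3 show piperazin-1-yl giving the weakest result, and the incoming benzyl(methyl)amino, lacking donor and acceptor, is closer in kind to the dimethylamino of compound 2 than to piperazin-1-yl, so a step back toward a lower number is expected, undoing much of an at least 30-fold higher number from compound 2 to compound 3 (1.47 log units; beyond the scatter). The expected step is an at least 12-fold lower number from compound 3 to compound 4 (1.07 log units; beyond the scatter). Compound 4 is therefore estimated at 2500 nM, with a range from 600 nM to 12000 nM.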

Compound 4, half-maximal inhibitory concentration: > 30000 nM
Compound 4 was reported as a limit; the forecaster's own chance of this, stated with the estimate: 10%; middle value at least 12-fold (1.07 log units) away from the limit.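

In this assay, phenyl in place of hydrogen on the saturated chain carbon bound to the sulfonamide nitrogen gives an at least 30-fold higher number from compound 2 to compound 4 (1.47 log units; beyond the scatter), and benzyl(methyl)amino in place of piperidin-1-yl gives an at least 9.0-fold higher number from compound 1 to compound 4 (0.95 log units; beyond the scatter). Piperazin-1-yl is thus no longer the only group on the sulfonyl sulfur that ends at the limit, and benzyl(methyl)amino reaches it with no hydrogen-bond donor or acceptor, so lacking these does not by itself keep the number low. The result for compound 4 is a limit of the assay, as is that for compound 3, so the step joining them cannot be read and the two cannot be ranked: the limit of > 30000 nM in this assay, at which 2 of the 4 values shown sit.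

The compounds shown leave open how the number changes with a group of intermediate size on the sulfonyl sulfur, such as ethyl(methyl)amino. They also leave open whether morpholin-4-yl would stay near compound 2 or join compound 3 and compound 4 at the limit.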